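A Mirror Image of an Inactive Compound

A few compounds are considered here, and "the series" means these few. Any claim that something is new, unique, unknown or untested is made for them only; others in the source may bear on it.

In a functional assay on HeLa cells (Homo sapiens) for cytotoxicity, read by MTT assay, with a stated time of 48 h (a higher number here means a weaker inhibitor, a lower number a stronger inhibitor), compound 1 `CCOC(=O)[C@@]1(C(=O)Nc2ccccc2)C[C@@H]1c1cc(OC)c(OC)c(OC)c1` gives > 100000 nM, which is a limit of the assay and not a number. Compound 2 `CCOC(=O)C1(C(=O)Nc2ccccc2)CC1c1cc(OC)c(OC)c(OC)c1` gives > 100000 nM; > 100000 nM (2 entries), again a limit and not a number. What separates these two as drawn is the fact that one of compounds 1 and 2 is drawn with a defined configuration and the other without, at the place where they differ.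

Compound 3 `CCOC(=O)[C@]1(C(=O)Nc2ccccc2)C[C@H]1c1cc(OC)c(OC)c(OC)c1` has not yet been measured. Its difference from compound 1 is the two compounds have the same atoms and bonds and differ only in configuration as drawn: 2 of 2 stereo elements differ (all stereocentres are inverted: mirror images); a stereocentre at a saturated ring carbon is drawn S in compound 1 and R in compound 3; a stereocentre at a saturated ring carbon is drawn R in compound 1 and S in compound 3: nothing leaves and nothing enters, the same atoms and bonds remain, and all stereocentres are inverted, so the two are mirror images. Since compound 1 offers only a limit, there is no exact starting number from which to measure a change. The best guide is compound 2, whose limit of > 100000 nM; > 100000 nM (2 entries) shows no measurable potency without a defined configuration. The expected size of a number no higher from compound 1 to compound 3 (the limit leaves the size open) is nothing beyond the usual scatter, with only a small chance of a stronger inhibitor. Compound 3 is estimated at 100000 nM, with an expected range of 30000 nM to 200000 nM, and the assay will most likely report only a limit again.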

Compound 3, half-maximal inhibitory concentration: > 100000 nM
Compound 3 gave a limit, no number; the forecaster's own chance of this, stated with the estimate: 85%; the middle value sits exactly at the limit.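

In this assay compound 3 gives > 100000 nM, which is a limit of the assay and not a number. Compound 1 also stands at a limit, so no step can be read between compound 1 and compound 3. The compounds shown leave open whether configuration has any effect on potency in this assay.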